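The source may hold more compounds than are shown below. What is called first, only, known or untested is meant among the compounds shown, and "the series" means these compounds.

Measured in a functional assay on SGC-7901 cells (Homo sapiens) for inhibition, read by MTT assay, with a stated time of 24 h; on this read-out lower numbers stand for stronger inhibition and higher numbers for weaker inhibition:
- compound 1 `CC1(C)[C@H]2CC[C@]1(C)N(Cc1cn(-c3ccccc3Br)nn1)C(=O)C2`: 500 nM
- compound 2 `CC1(C)[C@H]2CC[C@]1(C)N(Cc1cn(-c3cccc(C#N)c3)nn1)C(=O)C2`: 250 nM
- compound 3 `CC1(C)[C@H]2CC[C@]1(C)N(Cc1cn(-c3cccc(Cl)c3)nn1)C(=O)C2`: 510 nM

Compound 3, at 510 nM, stands level with compound 1, a 1.0-fold higher number from compound 1 to compound 3 (0.01 log units; within the scatter), and apart from compound 2, a 2.0-fold higher number from compound 2 to compound 3 (0.31 log units; beyond the scatter). Compound 4 `CC1(C)[C@H]2CC[C@]1(C)N(Cc1cn(-c3ccccc3O)nn1)C(=O)C2` carries 2-hydroxyphenyl in place of 3-chlorophenyl on an aromatic nitrogen. Changes at that nitrogen have so far moved the number little: a 2.0-fold lower number from compound 1 to compound 2 (0.30 log units; within the scatter) is the other measured step. For the measured compounds named here, no measured compound carries a hydroxyl group, so these steps are only a loose guide. No step beyond the scatter is therefore expected in this assay, and no direction is favoured. The expected step is a 1.0-fold lower number from compound 3 to compound 4 (0.01 log units; within the scatter). For compound 4 the estimated value is 500 nM, with an expected range from 170 nM to 1500 nM.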

Compound 4, half-maximal inhibitory concentration: 410 nM
Beside the measured number, compound 4's estimate is 1.2-fold (0.09 log units) above it; the range from low to high includes it.
By their numbers in this assay, from the lowest: compounds 2, 4, 1 and 3 (each within the scatter of the next, the first and the last beyond it).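

In this assay, 2-hydroxyphenyl brings a hydrogen-bond donor to this nitrogen, yet every step to compound 4 stays within the scatter (a 1.2-fold lower number from compound 3 to compound 4 (0.09 log units; within the scatter); a 1.6-fold higher number from compound 2 to compound 4 (0.21 log units; within the scatter); a 1.2-fold lower number from compound 1 to compound 4 (0.09 log units; within the scatter)). Hydroxy in place of bromo on an aromatic carbon is thus tolerated here, and compound 4 cannot be separated from compound 1, compound 2 or compound 3. Nothing available explains this tolerance.

Going by these compounds, whether an amine or a carboxylic acid on this phenyl ring would give a step beyond the scatter remains open. So does whether a methoxy group would behave like the hydroxyl.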